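From pyridin-4-yl to furan-2-yl in a cytotoxicity test

This account rests on a few compounds, and the source may have more. Where it says the series, first, only, none or still open, it means among the compounds named here.

- Compound 1 (`CCOC(=O)c1cc(/C=C/c2ccncc2)on1`): > 128000 nM
- Compound 2 (`CCOC(=O)c1cc(/C=C/c2ccc(OCc3ccccc3)cc2)on1`): > 128000 nM

Both results come from an ADME assay on Vero cells (Chlorocebus sabaeus) for cytotoxicity, with a stated time of 72 h (on this read-out lower numbers stand for stronger inhibition and higher numbers for weaker inhibition), and neither is an exact number. Compound 1 gives > 128000 nM in this measurement, which is a limit of the assay. Compound 2 gives > 128000 nM here, which is also a limit. Compound 1 therefore stands at the same mark as compound 2 (the limit of > 128000 nM in this assay, at which 2 of the 2 values shown sit) and has no exact value.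

Compound 3 (`CCOC(=O)c1cc(/C=C/c2ccco2)on1`) has not yet been measured. It keeps the core of compound 1 and changes one group (furan-2-yl in place of pyridin-4-yl on a double-bonded chain carbon bound to a double-bonded chain carbon), with furan-2-yl in place of pyridin-4-yl on a double-bonded chain carbon bound to a double-bonded chain carbon. For the measured compounds named here, no measured pair differs in just one place, so no measured step shows how large this change might be. In this assay no step beyond the scatter is expected, and no direction is favoured. This expectation rests on the shared result of compound 1 and compound 2 (the limit of > 128000 nM in this assay, at which 2 of the 2 values shown sit). The expected change is small (a number no higher from compound 1 to compound 3 (the limit leaves the size open)). The estimated value for compound 3 is 128000 nM (expected range 50000 nM to 256000 nM).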

Compound 3, half-maximal inhibitory concentration: > 128000 nM
Compound 3 gave a limit, no number; the forecaster's own chance of this, stated with the estimate: 75%; the middle value sits exactly at the limit.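

No step can be read from compound 1 to compound 3, since both results are limits and not numbers: the limit of > 128000 nM in this assay, at which 3 of the 3 values shown sit.

In this assay the compounds shown leave open how far each true value lies from that limit, and whether furan-2-yl in place of pyridin-4-yl changes the result at all.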